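This account rests on a few compounds, and the source may have more. Where it says the series, first, only, none or still open, it means among the compounds named here.

Compound 2 `ClCc1ccc(Cn2cnc3ncnc(Cl)c32)cc1` is a fused two-ring core with a benzyl-type arm attached to it; in a functional assay on LOX IMVI cells (Homo sapiens) for cytotoxicity, read by sulforhodamine B assay, with a stated time of 48 h (on this read-out higher numbers stand for weaker inhibition of growth and lower numbers for stronger inhibition of growth), compound 2 gives "not determined" (no result reported), so nothing can be said about where it stands on this read-out; there is simply no number for it. A relative, compound 1 `ClCc1ccccc1Cn1cnc2nc(Cl)nc(Cl)c21`, shares the same substituted core but carries its arm in a different arrangement; in this assay compound 1 gives 350 nM. Compound 3 `ClCc1ccc(Cn2cnc3nc(Cl)nc(Cl)c32)cc1` is compound 2 with a single change: chloro in place of hydrogen on an aromatic carbon. Going by the values given here, no measured pair in this set isolates that change, so no step size can be drawn from the data for this assay, neither upward nor downward. Compound 3 has the same core as compound 1, whose result of 350 nM is the only anchor available. Compound 3 is expected to give about 500 nM in this assay, within a range from 150 nM to 2000 nM.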

Compound 3, concentration for total growth inhibition: 3230 nM
Beside the measured number, compound 3's estimate is 6.5-fold (0.81 log units) below it; measured number above the stated range.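

Going by these compounds alone, compound 2 gives no number in this assay, so no step from it to compound 3 can be read. The compounds shown leave open what chloro in place of hydrogen does to growth inhibition. Nothing shown here offers an explanation for the result of compound 3.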